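Halogen exchange on an aromatic carbon: compound 2 to compound 3

The source may report more compounds than this note shows. Statements on the series, on what has been measured and on what is new or still open speak of the compounds shown alone.

Measured so far:
compound 1 `COc1cccc(NC(=O)N[C@@H](C)c2ccccc2)c1` — 99%
compound 2 `C[C@H](NC(=O)Nc1cccc(F)c1)c1ccccc1` — 88%

In an ADME assay on the whole organism with Oryza sativa as the target, tested at 10 uM (on this read-out higher numbers stand for a weaker effect at the one concentration tested and lower numbers for a stronger effect), compound 2 gives 88%, the lowest of the two numbers; the nearest is compound 1, which gives 99%. Compound 3 `C[C@H](NC(=O)Nc1cccc(I)c1)c1ccccc1` differs from compound 2 as iodo in place of fluoro on an aromatic carbon. Among the compounds with values here, the only measured step, a number 11 percentage points lower from compound 1 to compound 2 (beyond the scatter), concerns a different exchange and offers no direct guide to one halogen replacing another. Within the data shown here, no measured step bears on this change, so nothing beyond the scatter is expected. Compound 3 is therefore expected to show a number 3 percentage points lower from compound 2 to compound 3 (within the scatter). The estimate for compound 3 is 85%, within 65% to 100%.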

Compound 3, a percentage reported as activity, at one concentration (the size of the read-out at that concentration, not a potency): 93%
Compound 3: the middle estimate sits 8 percentage points below what was measured, within the range that was stated.
By their numbers in this assay, from the lowest: compounds 2, 3 and 1 (each within the scatter of the next, the first and the last beyond it).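

In this assay, a halogen exchange on an aromatic carbon meta to a large group gives a number 5 percentage points higher from compound 2 to compound 3 (within the scatter) and so leaves iodo and fluoro unseparated at this position. Iodo in place of methoxy gives a number 6 percentage points lower from compound 1 to compound 3 (within the scatter) and thus leaves only the fluoro and methoxy pair separated beyond the scatter. No measured evidence accounts for these numbers.

Open, from the compounds shown here alone, is whether an amine, a carboxylic acid or a longer chain at this position would give a number beyond the scatter of all three compounds. Going by these compounds, whether chloro or bromo would fall with fluoro and iodo also stays open.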